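Fluoro placement across the series

The compounds below may be only part of what the source reports. "The series", "measured", "known", "first", "only" and "open" are said of these compounds alone.

Compound 1 `CN(C)c1ccc(C#Cc2ccccc2F)cc1` gives 39 nM in a functional assay on LS174T cells (Homo sapiens) for antiproliferative activity, with a stated time of 4 days; on this read-out lower numbers stand for stronger inhibition and higher numbers for weaker inhibition. Compound 2 `CN(C)c1ccc(C#Cc2cccc(F)c2)cc1` returns only a limit of the assay in this assay, > 3000 nM. Compound 3 `CN(C)c1ccc(C#Cc2cc(F)cc(F)c2)cc1` likewise returns only a limit, > 3000 nM. The step that the two limits leave unreadable from compound 2 to compound 3 is thus unreadable, as both values sit at the limit of > 3000 nM in this assay, at which 2 of the 3 values shown sit. The change from compound 2 to compound 3 is fluoro in place of hydrogen on an aromatic carbon. Compounds 1 and 2 share the same atoms joined differently; the difference between the two cores is not broken down here. Compound 4 `CN(C)c1ccc(C#Cc2c(F)cccc2F)cc1` is not yet measured and differs from compound 1 by fluoro in place of hydrogen on an aromatic carbon, the same kind of change as from compound 2 to compound 3, though here the place is ortho to a large group rather than meta to it. Since compound 1 gives 39 nM, compound 4 is expected to stay near it, a step of a 1.5-fold higher number from compound 1 to compound 4 (0.19 log units; within the scatter), the earlier step offering no readable size for comparison. Compound 4 is estimated at 60 nM, between 15 nM and 400 nM.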

Compound 4, half-maximal inhibitory concentration: 23 nM
Compound 4: middle estimate off by 2.6-fold (0.42 log units), on the high side; the range from low to high includes it.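

In this assay, the added fluoro on the core of compound 1 stays within the scatter, with a 1.7-fold lower number from compound 1 to compound 4 (0.23 log units; within the scatter). The same change on the other core cannot be read, as compound 2 and compound 3 each return a limit and not a number: the limit of > 3000 nM in this assay, at which 2 of the 4 values shown sit. The change is therefore seen to leave the read-out in place on the core of compound 1 only, and nothing shows whether that result carries over to the core of compound 2.

As far as these compounds go, whether chloro, methoxy or a carboxylic acid in the same place would read like fluoro stays open. Also open, from the compounds shown here alone, is whether any group on the core of compound 2 gives a value off the limit.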